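Swapping a Trifluoromethyl for Chloro on an Aryl Ring

The source may hold more compounds than are shown below. What is called first, only, known or untested is meant among the compounds shown, and "the series" means these compounds.

Of the compounds shown here, two sharing one core have been measured in an assay on CHO cells for displacement of a labelled ligand from prostaglandin E2 receptor EP1 subtype (Homo sapiens); a higher number here means a weaker inhibitor, a lower number a stronger inhibitor. Compound 1, `CCc1ccccc1N(Cc1nnc(Cc2ccc(OC)cc2)o1)S(=O)(=O)c1ccc(C)cc1`, gives 126 nM; 126 nM (2 entries) in this assay. Compound 2, `COc1ccc(Cc2nnc(CN(c3cccc(C(F)(F)F)c3C)S(=O)(=O)c3ccc(C)cc3)o2)cc1`, gives 63.1 nM in this assay. For the measured compounds named here, the two values differ, but no step between them has been worked out, so only the two numbers themselves can be read from them. Going by the values given here, for compound 2, this is the only value shown; a further entry exists for it that does not give a single number.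

Compound 3, `COc1ccc(Cc2nnc(CN(c3cccc(Cl)c3C)S(=O)(=O)c3ccc(C)cc3)o2)cc1`, is not yet measured in this assay. It differs from compound 2 in one place: chloro in place of trifluoromethyl on an aromatic carbon. Both groups that change hands carry no donors, no acceptors and no charge, and the rest of the molecule is untouched.

Among the compounds with values here, no measured pair in this set shows what such a swap does here, so the expectation rests on compound 2 alone. The step from compound 2 to compound 3 is expected to be small, a 1.3-fold higher number from compound 2 to compound 3 (0.10 log units; within the scatter), not clearly beyond the usual scatter in either direction. Compound 3 is therefore estimated at 80 nM in this assay, with a plausible range from 30 nM to 200 nM.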

Compound 3, half-maximal inhibitory concentration: 6.31 nM
Compound 3: middle estimate off by 13-fold (1.10 log units), on the high side; the measured number lies below the stated range.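

In this assay, the change at this aromatic carbon, ortho to a methyl group, gives a 10-fold lower number from compound 2 to compound 3 (1.00 log units; beyond the scatter) and takes the number well outside the usual scatter, so this position is not indifferent to which group it carries. The earlier compounds shown here could not show this, as they contained no pair differing in one place. The step also shows that two groups with no hydrogen-bond donors, no hydrogen-bond acceptors and no net charge can still give clearly different numbers here, with chloro, the group of one heavy atom, giving the lower number in this single pair, and nothing measured here explains the difference.

The compounds shown leave open how a bromo, a methoxy or a plain hydrogen on this carbon would compare with chloro and trifluoromethyl, and so whether the number tracks the heavy-atom count of the group at all. They also leave open whether the same swap would give a step of similar size if the neighbouring methyl group were replaced by an ethyl group or a hydrogen.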